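A few compounds are considered here, and "the series" means these few. Any claim that something is new, unique, unknown or untested is made for them only; others in the source may bear on it.

Three compounds share one core and were tested in a functional assay on MKN-45 cells (Homo sapiens) for antiproliferative activity, tested at 1 uM; a higher number here means more inhibition at the concentration tested (going by the name of the read-out), a lower number less inhibition. Compound 1 `Cc1c(CO/N=C/c2c(-c3ccccc3)nn(-c3ccccc3)c2Oc2ccc(Cl)cc2)cccc1-c1ccccc1` gives -15%. Compound 2 `Cc1nn(-c2ccccc2)c(Oc2ccc(Cl)cc2)c1/C=N/OCc1ccc(C(=O)OC(C)(C)C)cc1` gives -9.9%. Compound 3 `Cc1ccc(CO/N=C/c2c(C)nn(C)c2Oc2ccc(Cl)cc2)cc1` gives 30.4%, the highest of the three numbers, and its distance from both compound 2 and compound 1 is beyond the usual scatter. Compound 4 `Cc1nn(C)c(Oc2ccc(Cl)cc2)c1/C=N/OCc1ccc([N+](=O)[O-])cc1` has not yet been measured. It differs from compound 3 in one place: nitro in place of methyl on an aromatic carbon. Among the compounds with values here, no two measured compounds differ in only one place, so there is no measured step of this kind to go by. The step of a number 10.4 percentage points lower from compound 3 to compound 4 (beyond the scatter) is estimated to be small and downward, near the edge of the usual scatter. For compound 4 the expected value is 20%, within a range from -15% to 50%.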

Compound 4, a percentage reported as inhibition, at one concentration (the size of the read-out at that concentration, not a potency): 24.6%
Estimate against measurement, compound 4: 4.6 percentage points below; the measured number falls inside the stated range.
By their numbers in this assay, from the lowest: compounds 1 and 2 (each within the scatter of the next); then compounds 4 and 3 (each within the scatter of the next).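

In this assay the change from 4-methylphenyl to 4-nitrophenyl gives a number 5.8 percentage points lower from compound 3 to compound 4 (within the scatter). Within the data shown here, this is the first comparison here between compounds that differ in one place, and it shows that nitro, with more heavy atoms and two hydrogen-bond acceptors, can replace methyl on this aromatic carbon without a readable change in the number. No measurement shown accounts for this result. From the compounds shown here alone, whether an amine or a carboxylic acid at this position would also leave the number unchanged remains open. So does whether the same swap would read alike with other groups on the shared core.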